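Moving a Fluorine Around an Amide Ring

The compounds below may be only part of what the source reports. "The series", "measured", "known", "first", "only" and "open" are said of these compounds alone.

Compound 3 `COc1cc(N(C)C(=O)c2cccc(F)c2)cc(OC)c1OC` carries a 3-fluorophenyl group on its amide carbonyl. In a functional assay on ONS-76 cells (Homo sapiens) for cytotoxicity, read by MTT assay, with a stated time of 72 h (on this read-out higher numbers stand for weaker inhibition and lower numbers for stronger inhibition), compound 3 gives only a limit, >= 125000 nM. Its nitro-bearing relative, compound 1 `COc1cc(N(C)C(=O)c2cccc([N+](=O)[O-])c2)cc(OC)c1OC`, stands at the same limit. In this assay compound 1 gives >= 125000 nM. The urea compound 2 `COc1cc(NC(=O)Nc2cccc3c2CCC3)cc(OC)c1OC`, built with a different linker, also reaches no number. In this assay compound 2 gives >= 125000 nM. Among the compounds with values here, the one measured step that touches compound 3 is a step that the two limits leave unreadable from compound 1 to compound 3, and its size cannot be read because all three values sit at the limit of >= 125000 nM in this assay, at which 3 of the 3 values shown sit.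

Compound 4 `COc1cc(N(C)C(=O)c2ccc(F)cc2)cc(OC)c1OC` differs from compound 3 by 4-fluorophenyl in place of 3-fluorophenyl on a carbonyl carbon. No measured step shows what this change does; what is shown is three compounds that all stop at the limit. Compound 4 is therefore expected to stay near that limit as well. The expected step is a number no higher from compound 3 to compound 4 (the limit leaves the size open). The estimate for compound 4 is 125000 nM, within 40000 nM to 300000 nM.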

Compound 4, half-maximal inhibitory concentration: >= 125000 nM
Compound 4: no number, only a limit (the forecaster's own chance of this, stated with the estimate: 80%); the middle value sits exactly at the limit.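

Compound 3 and compound 4 both stop at a limit rather than a number in this assay, so no step between them can be read: the limit of >= 125000 nM in this assay, at which 4 of the 4 values shown sit.

The compounds shown leave open whether the 3-fluorophenyl and 4-fluorophenyl groups differ at all, and which change to the shared core would yield an actual number.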